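A few compounds are considered here, and "the series" means these few. Any claim that something is new, unique, unknown or untested is made for them only; others in the source may bear on it.

Measured compounds:
Compound 1, `Cc1cccc(C(=O)c2c(OCC(=O)Nc3ccc(S(N)(=O)=O)cc3C)ccc3ccccc23)c1` — in an ADME assay on C8166 cells (Homo sapiens) for cytotoxicity, read by colorimetric assay and MTT assay (a lower number here means that less compound is tolerated, a higher number that more compound is tolerated), compound 1 gives 40400 nM.
Compound 2, `Cc1cc(C)cc(C(=O)c2c(OCC(=O)Nc3ccc(S(N)(=O)=O)cc3C)ccc3ccccc23)c1` — in this assay compound 2 gives 39100 nM.
Compound 3, `Cc1cccc(C(=O)c2c(OCC(=O)Nc3ccc(S(N)(=O)=O)cc3C)ccc3cc(Br)ccc23)c1` — in this assay compound 3 gives 6800 nM.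

Among the measured compounds shown here, compound 3 stands lowest of the three in this assay; the one measured step that leads to it is a 5.9-fold lower number from compound 1 to compound 3 (0.77 log units; beyond the scatter), so compound 3 is the least tolerated of the set. Compound 4, `Cc1ccc(C(=O)c2c(OCC(=O)Nc3ccc(S(N)(=O)=O)cc3C)ccc3cc(Br)ccc23)cc1C`, differs from compound 3 by methyl in place of hydrogen on an aromatic carbon. For the measured compounds named here, one measured step bears on this: a 1.0-fold lower number from compound 1 to compound 2 (0.01 log units; within the scatter), a methyl added to the same phenyl in the same way, which stayed within the scatter. A similar outcome is therefore expected here, with no step beyond the scatter in this assay in either direction. Compound 4 is estimated at 6800 nM, within 3000 nM to 15000 nM, a step of no change at the digits printed from compound 3 to compound 4 (within the scatter).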

Compound 4, half-maximal cytotoxic concentration: 85200 nM
Compound 4: middle estimate off by 13-fold (1.10 log units), on the low side, outside the stated range (above it).
By their numbers in this assay, from the lowest: compound 3; then compounds 2 and 1 (each within the scatter of the next); then compound 4.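

Turning 3-methylphenyl into 3,4-dimethylphenyl on the bromo-bearing core gives a 13-fold higher number from compound 3 to compound 4 (1.10 log units; beyond the scatter) in this assay, so a single methyl on this phenyl can raise the tolerated concentration strongly. The same kind of change therefore has no fixed size of effect across these compounds: the same change on two cores in this assay, a 1.0-fold lower number (0.01 log units; within the scatter) from compound 1 to compound 2 and a 13-fold higher number (1.10 log units; beyond the scatter) from compound 3 to compound 4, 13-fold (1.11 log units) apart, beyond the scatter of two such steps

The two steps differ both in the bromo on the core and in the ring carbon that takes the methyl, and the compounds shown do not separate these two differences. On these data alone, how an ethyl, a methoxy or an amine on this ring carbon would read also remains open.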